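The source may report more compounds than this note shows. Statements on the series, on what has been measured and on what is new or still open speak of the compounds shown alone.

Working notes on the series. Compound 1, `CC(Sc1nc2c(cnn2C)c(=O)n1-c1ccccc1)c1cccc(F)c1`, gives 128 nM in an assay on isolated protein for inhibition of Retinaldehyde dehydrogenase 3 (Homo sapiens); a higher number here means a weaker inhibitor, a lower number a stronger inhibitor. Compound 2, `CC(Sc1nc2nn(C3COC3)cc2c(=O)n1-c1ccccc1)c1cccnc1`, gives 250 nM in this assay. Of the two numbers measured, compound 1 carries the lowest, with compound 2 nearest to it and the gap inside the usual scatter. Compound 3, `CC(Sc1nc2c(cnn2C)c(=O)n1-c1ccccc1)c1cncnc1`, is not yet measured. It differs from compound 1 in one place: pyrimidin-5-yl in place of 3-fluorophenyl on a saturated chain carbon bound to a saturated chain carbon and a sulfur. Among the measured compounds shown here, no measured pair shows this change, so no step is known for it; a moderate loss is expected, a 3.1-fold higher number from compound 1 to compound 3 (0.49 log units; beyond the scatter) in this assay. Compound 3 is estimated at 400 nM, with a range from 150 nM to 1200 nM.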

Compound 3, half-maximal inhibitory concentration: 100 nM
Estimate against measurement, compound 3: 4.0-fold (0.60 log units) above; the whole stated range lies above it.
By their numbers in this assay, from the lowest: compounds 3, 1 and 2 (each within the scatter of the next, the first and the last beyond it).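

On the saturated chain carbon bound to a saturated chain carbon and a sulfur, pyrimidin-5-yl in place of 3-fluorophenyl gives a 1.3-fold lower number from compound 1 to compound 3 (0.11 log units; within the scatter) in this assay. This position therefore accepts a ring with 2 hetero atoms and 2 hydrogen-bond acceptors in place of a carbon-only ring bearing fluorine, with the two numbers staying within the scatter. No measured evidence bears on the reason for this result.

On these data alone, whether an aliphatic amine or a carboxylic acid on this carbon would also hold the number remains open. So does whether pyrimidin-5-yl reads the same on the core of compound 2.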